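The source may report more compounds than this note shows. Statements on the series, on what has been measured and on what is new or still open speak of the compounds shown alone.

Working notes on the series. Compound 1 `O=C(NCCCNc1nccc(-c2c(-c3cccc(F)c3)nc3sccn23)n1)c1ccc(F)cc1` carries a (4-fluorophenyl)carbonyl on the chain amine, compound 2 `O=S(=O)(NCCCNc1nccc(-c2c(-c3cccc(F)c3)nc3sccn23)n1)c1cccc(F)c1` a (3-fluorophenyl)sulfonyl on the same chain, and compound 3 `O=C(NCCNc1nccc(-c2c(-c3cccc(F)c3)nc3sccn23)n1)c1ccc(C(F)(F)F)cc1` a shorter chain ending in a trifluoromethyl-bearing aryl carbonyl. In a functional assay on SK-MEL-28 cells (Homo sapiens) for cytotoxicity, read by MTT assay (on this read-out higher numbers stand for weaker inhibition and lower numbers for stronger inhibition), compound 2 gives 8550 nM, the lowest of the two numbers. Compound 3 gives 9260 nM, within the scatter of compound 2. Compound 1 reaches only the limit of > 20000 nM in this assay. For the measured compounds named here, the one measured step, an at least 2.3-fold lower number from compound 1 to compound 2 (0.36 log units; beyond the scatter), is a bound because of the limit of > 20000 nM in this assay, at which 1 of the 3 values shown sits.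

Compound 4 `O=S(=O)(NCCNc1nccc(-c2c(-c3cccc(F)c3)nc3sccn23)n1)c1ccc(F)cc1` differs from compound 2 as follows: ((4-fluorophenyl)sulfonyl)amino in place of (((3-fluorophenyl)sulfonyl)amino)methyl on a saturated chain carbon, two bonds along the chain from a nitrogen on an aromatic ring. The measured step from compound 1 to compound 2 swaps (4-fluorophenyl)carbonyl for (3-fluorophenyl)sulfonyl in one move, so it does not separate the sulfonyl from the fluorine placement; compound 3 beside compound 1 shows a shorter chain only together with a different aryl group. Going by the values given here, no measured step isolates either element changed here. Compound 4 is therefore expected to stay near compound 2, estimated at 8000 nM with a range of 3000 nM to 20000 nM. The expected step of a 1.1-fold lower number from compound 2 to compound 4 (0.03 log units; within the scatter) lies within the scatter.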

Compound 4, half-maximal inhibitory concentration: 9450 nM
Compound 4: the middle estimate sits 1.2-fold (0.07 log units) below what was measured, within the range that was stated.
By their numbers in this assay, from the lowest: compounds 2, 3 and 4 (each within the scatter of the next). At a limit, above all of these: compound 1.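

In this assay, the change at this position, on a saturated chain carbon, two bonds along the chain from a nitrogen on an aromatic ring, gives a 1.1-fold higher number from compound 2 to compound 4 (0.04 log units; within the scatter), so the sulfonyl pair shows no readable difference when chain length and fluorine placement change together. On the same chain, the change on the amine nitrogen gives a 1.0-fold higher number from compound 3 to compound 4 (0.01 log units; within the scatter), so a (4-fluorophenyl)sulfonyl and a (4-(trifluoromethyl)phenyl)carbonyl are not told apart by this read-out, although the aryl group differs along with the linking group. The remaining step, an at least 2.1-fold lower number from compound 1 to compound 4 (0.32 log units; beyond the scatter), is only a bound, and it again sets compound 1 apart from the other compounds: the limit of > 20000 nM in this assay, at which 1 of the 4 values shown sits.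

The compounds shown leave open whether the sulfonyl, the chain length or the fluorine placement accounts for the separation of compound 1, as no pair here changes one of these alone. Also open, from the compounds shown here alone, is how a longer chain, or an amine or a carboxylic acid at the chain end in place of the aryl sulfonyl group, would read in this assay.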